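This account rests on a few compounds, and the source may have more. Where it says the series, first, only, none or still open, it means among the compounds named here.

Compound 1 `COc1cc(-c2ccnc3cc(-c4ccc(C)cc4)nn23)cc(OC)c1OC` — in a functional assay on HCT-116 cells (Homo sapiens) for inhibition, read by CCK-8 assay, with a stated time of 48 h (a higher number here means a weaker inhibitor, a lower number a stronger inhibitor), compound 1 gives 48 nM.
Compound 2 `COc1cc(-c2ccnc3c(-c4ccc(C)cc4)cnn23)cc(OC)c1OC` — in this assay compound 2 gives > 10000 nM, a limit of the assay rather than a number.

Going by the values given here, compound 1 holds the only true number in this assay among the two measured compounds; the other value is a limit. For compound 2 the assay reports (the limit of > 10000 nM in this assay, at which 1 of the 2 values shown sits), so how far apart the two compounds really are cannot be said. Among the compounds with values here, compound 2 carries the same 4-methylphenyl group on a different carbon of the shared core, and no single-point step between the two is available.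

The step under review is from compound 1 to compound 3 `COc1cc(-c2ccnc3cc(-c4cccc(C#N)c4)nn23)cc(OC)c1OC`. The change is 3-cyanophenyl in place of 4-methylphenyl on an aromatic carbon. Within the data shown here, no measured step of this kind exists here, so the size and direction of the effect in this assay are open. The expectation is a step from compound 1 to compound 3 of roughly a 2.5-fold higher number from compound 1 to compound 3 (0.40 log units; beyond the scatter), with some loss of potency considered more likely than a gain, but the estimate carries a wide range. Compound 3 is expected to give about 120 nM in this assay, somewhere between 25 nM and 600 nM.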

Compound 3, half-maximal inhibitory concentration: > 10000 nM
Compound 3 gave a limit, no number (the forecaster's own chance of this, stated with the estimate: 10%); middle value at least 83-fold (1.92 log units) away from the limit.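

Placed on the aromatic carbon of the five-membered aromatic ring, 3-cyanophenyl in place of 4-methylphenyl gives an at least 200-fold higher number from compound 1 to compound 3 (2.31 log units; beyond the scatter) in this assay, so this position does not accept every substituted phenyl group. Before this result, only moving the 4-methylphenyl group to a different carbon of the shared core had gone with a limit, whereas compound 3 keeps the attachment point of compound 1 and changes only the group itself. Compound 3 gives > 10000 nM, a limit of the assay and not a number, so the step has no upper bound and the compound sits at the same limit as compound 2: the limit of > 10000 nM in this assay, at which 2 of the 3 values shown sit.

The change both removes the 4-methyl group and brings in a nitrile at a different place on the phenyl ring, so this single step cannot separate the two. From the compounds shown here alone, whether 4-cyanophenyl, 3-methylphenyl, unsubstituted phenyl or a phenyl ring bearing an amine or a methoxy group would keep a measurable number in this assay remains open.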